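The source may report more compounds than this note shows. Statements on the series, on what has been measured and on what is new or still open speak of the compounds shown alone.

- compound 1 `Cc1cc(Nc2cc(-c3ccccc3)[nH]n2)n2nc(SCc3c(Cl)cccc3Cl)nc2n1` gives 5180 nM
- compound 2 `Cc1cc(Nc2cc(-c3ccccc3)[nH]n2)n2nc(SCC3CCCCC3)nc2n1` gives > 50000 nM (a limit of the assay, not a number)
- compound 3 `Cc1cc(Nc2cc(-c3ccccc3)[nH]n2)n2nc(SCC(=O)c3ccccc3)nc2n1` gives 4450 nM

All three compounds were tested in a functional assay on PC-9 cells (Homo sapiens) for inhibition, read by MTT assay, with a stated time of 72 h (a higher number here means a weaker inhibitor, a lower number a stronger inhibitor), and share one core. Compound 3 stands level with compound 1: the data show a 1.2-fold lower number from compound 1 to compound 3 (0.07 log units; within the scatter) and so the two cannot be told apart. Compound 2 yielded only a limit.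

The next compound is compound 4 `Cc1cc(Nc2cc(-c3ccccc3)[nH]n2)n2nc(SCCCc3ccccc3)nc2n1` which keeps the core of compound 3 and changes one group. The counted difference reads phenethyl in place of benzoyl on a saturated chain carbon bound to a sulfur and in words this is phenethyl in place of benzoyl on a saturated chain carbon bound to a sulfur. Both groups hold a six-membered aromatic ring of carbon only.

Among the measured compounds shown here, three measured steps bear on this change. Swapping one ring-bearing group for another did little, as a 1.2-fold lower number from compound 1 to compound 3 (0.07 log units; within the scatter) shows. Cyclohexyl, which has no aromatic ring, behaved differently, with an at least 9.6-fold higher number from compound 1 to compound 2 (0.98 log units; beyond the scatter) and an at least 11-fold lower number from compound 2 to compound 3 (1.05 log units; beyond the scatter) on record. Among these three compounds, then, the two with an aromatic ring gave numbers, and no compound goes against that.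

Since compound 4 keeps an aromatic ring, no change beyond the scatter is expected, and the estimated move is a 1.3-fold higher number from compound 3 to compound 4 (0.13 log units; within the scatter) in this assay overall. The range stays wider on the weaker side, given the size of an at least 11-fold lower number from compound 2 to compound 3 (1.05 log units; beyond the scatter) at this same place.

Compound 4 is estimated at 6000 nM with an expected range from 2000 nM to 25000 nM in this measurement.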

Compound 4, half-maximal inhibitory concentration: 5030 nM
Beside the measured number, compound 4's estimate is 1.2-fold (0.08 log units) above it; low and high end bracket the measured number.
By their numbers in this assay, from the lowest: compounds 3, 4 and 1 (each within the scatter of the next). At a limit, above all of these: compound 2.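

Phenethyl in place of benzoyl takes away the carbonyl, and with it the one hydrogen-bond acceptor of the leaving group, yet in this assay the result is a 1.1-fold higher number from compound 3 to compound 4 (0.05 log units; within the scatter), so among these compounds the carbonyl is not needed to hold the number where it stands. The same holds against the 2,6-dichlorophenyl group, with a 1.0-fold lower number from compound 1 to compound 4 (0.01 log units; within the scatter), which makes three different groups carrying an aromatic ring at this place that cannot be told apart, and none of the compounds shown goes against that. Phenethyl in place of cyclohexyl brings an aromatic ring back and gives an at least 9.9-fold lower number from compound 2 to compound 4 (0.99 log units; beyond the scatter), a step that starts from a limit of the assay and not a number: the limit of > 50000 nM in this assay, at which 1 of the 4 values shown sits.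

The link between an aromatic ring and a measurable number still rests on a single compound without one, so a plain longer alkyl chain in place of cyclohexyl would test it further. From the compounds shown here alone, how a pyridine ring, an amine or a carboxylic acid would fare on this chain is also open, as all three groups that gave numbers end in a ring of carbon only.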